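The compounds below may be only part of what the source reports. "The series", "measured", "known", "first", "only" and "open" are said of these compounds alone.

Of the compounds shown here, three that share one core have been tested in an ADME assay on microsomes from liver (Mus musculus) for metabolic stability, read by LC-MS, using NADPH, with a stated time of 60 min, tested at 1 uM, in the presence of a further agent that is not named here; a lower number here means slower removal, a higher number faster removal of the compound. Compound 1 `Cc1ccc2nc(-c3ccccn3)c(Nc3ccc4c(c3)OCCO4)n2c1` gives 411 uL/min, compound 2 `Fc1cccc(Nc2c(-c3ccccn3)nc3ccccn23)c1` gives 242 uL/min, and compound 3 `COc1ccn2c(Nc3ccccc3F)c(-c3ccccn3)nc2c1` gives 133 uL/min. Of these three numbers, compound 3 has the lowest; its nearest neighbour is compound 2, and that gap lies within the usual scatter of repeated measurements, while the gap to compound 1 lies beyond it. Compound 4 `COc1ccn2c(Nc3ccc(F)cn3)c(-c3ccccn3)nc2c1` has not yet been measured. It differs from compound 3 in one place: 5-fluoropyridin-2-yl in place of 2-fluorophenyl on a nitrogen on an aromatic ring. Among the measured compounds shown here, no pair of measured compounds shows this same change, so there is no direct precedent for how the intrinsic clearance will move. The expected step of a 1.3-fold lower number from compound 3 to compound 4 (0.12 log units; within the scatter) is small, towards a lower number or none beyond the scatter. Compound 4 is therefore estimated to give about 100 uL/min in this assay, with a range from 50 uL/min to 200 uL/min.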

Compound 4, intrinsic clearance in a liver preparation (reported as CLH), per the amount of preparation that the assay uses: 81 uL/min
Compound 4: middle estimate off by 1.2-fold (0.09 log units), on the high side; the range from low to high includes it.
By their numbers in this assay, from the lowest: compounds 4, 3, 2 and 1 (each within the scatter of the next, the first and the last beyond it).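

Among the compounds shown here, at this place, on a nitrogen on an aromatic ring, putting 5-fluoropyridin-2-yl in place of 2-fluorophenyl gives in this assay the first measured step on the shared core: a 1.6-fold lower number from compound 3 to compound 4 (0.22 log units; within the scatter). A ring nitrogen and a hydrogen-bond acceptor thus enter here, and the intrinsic clearance does not move beyond the usual scatter, although the swap also gives the fluorine a different numbered place on its ring, so one step cannot separate these two differences. Nothing measured here explains the result.

From the compounds shown here alone, whether the same swap would give a similar step with the other groups on the core of compound 1 or compound 2 remains open. Also open, going by these compounds, is how a pyridin-2-yl without fluorine, or one carrying an amine or a carboxylic acid, would behave at this place.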